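The source may hold more compounds than are shown below. What is called first, only, known or untested is meant among the compounds shown, and "the series" means these compounds.

Cytotoxicity notes on the series, read in an ADME assay on MT2 cells (Homo sapiens) for cytotoxicity, read by XTT assay, with a stated time of 4 days; a lower number here means that less compound is tolerated, a higher number that more compound is tolerated:

compound 1 `Cc1ccc(NC(=O)C(=O)NC(c2nc(C)c(CCO)s2)C2CCCCN2)c(F)c1`: > 78800 nM, a limit of the assay
compound 2 `Cc1nc(C(NC(=O)C(=O)Nc2ccc(F)c(Cl)c2)C2CCCCN2)sc1CCO`: 94700 nM
compound 3 `Cc1nc(C(NC(=O)C(=O)Nc2ccc(Cl)cc2)C2CCCCN2)sc1CCO`: > 62000 nM, a limit of the assay

Compound 3 sits at a limit: its value of > 62000 nM is a limit of this assay and not a number. Of the three values shown, two are limits, as the limit of > 62000 nM in this assay, at which 1 of the 3 values shown sits, and the limit of > 78800 nM in this assay, at which 1 of the 3 values shown sits, state, and compound 2 alone gives a number. The measured steps onto and off compound 3 cannot be read: a step that the two limits leave unreadable from compound 1 to compound 3 and a step that the limit leaves unreadable from compound 2 to compound 3, and likewise a step that the limit leaves unreadable from compound 1 to compound 2 between the other two.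

Compound 4 `Cc1ccc(NC(=O)C(=O)NC(c2nc(C)c(CCO)s2)C2CCCCN2)cc1F` is the next member. Against compound 3 the change is 3-fluoro-4-methylphenyl in place of 4-chlorophenyl on an amide-type nitrogen. Within the data shown here, the steps that bear on it are the two aryl exchanges ending at compound 3, both unreadable, and the aryl exchange from compound 1, which already carries a fluoro-methylphenyl, to compound 2, also unreadable. All three measured compounds tolerate compound up to the top of the assay, so no step beyond the scatter is expected in this assay, in either direction; the expected step is a step that the limit leaves unreadable from compound 3 to compound 4. Compound 4 is therefore estimated at 80000 nM, within 40000 nM to 200000 nM, most likely reported again as a limit.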

Compound 4, half-maximal cytotoxic concentration: 85000 nM
Compound 4: the middle estimate sits 1.1-fold (0.03 log units) below what was measured, within the range that was stated.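

In this assay, among these compounds, the exchange of 3-chloro-4-fluorophenyl for 3-fluoro-4-methylphenyl on the amide-type nitrogen gives a 1.1-fold lower number from compound 2 to compound 4 (0.05 log units; within the scatter), the first step at this position that can be read. Among the compounds shown here, compound 2 and compound 4 thus supply the only two numbers at this position, and this pair shows that the exchange of one chlorine-bearing and one methyl-bearing phenyl, each also carrying fluorine, leaves the reading within the scatter. The steps to compound 4 from compound 3 and from compound 1 cannot be read, so this finding rests on one pair alone and extends to no other aryl group.

From the compounds shown here alone, whether the 4-chlorophenyl of compound 3 or the 2-fluoro-4-methylphenyl of compound 1 would stand apart from the other two aryl groups stays open, since neither compound gives a number in this assay. Also open is how a phenyl carrying an amine or a carboxylic acid on this amide-type nitrogen would read, since every aryl group shown bears only halogen or methyl.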